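The source may hold more compounds than are shown below. What is called first, only, known or untested is meant among the compounds shown, and "the series" means these compounds.

Measured compounds:
compound 1, `N=C(N)N/N=C\c1ccccc1OCc1ccc2no[n+]([O-])c2c1`, in an ADME assay on cells (Erythrocyte, Homo sapiens), read by spectrophotometry and hemolysis, with a stated time of 24 h; a higher number here means a weaker inhibitor, a lower number a stronger inhibitor: 58 uM
compound 2, `NC(=S)N/N=C\c1ccccc1OCc1ccc2no[n+]([O-])c2c1`: 189 uM
compound 3, `CC1(C)[N+]([O-])=c2ccc(COc3ccccc3/C=N\NC(=N)N)cc2=[N+]1[O-]`: 114 uM

Going by the values given here, the one change with a measured step runs from compound 1 to compound 2: a group of 3 heavy atoms (1 carbon, 1 nitrogen, 1 sulfur; no ring) in place of a group of 3 heavy atoms (1 carbon, 2 nitrogen; no ring), on an amine nitrogen. That step was a 3.3-fold higher number from compound 1 to compound 2 (0.51 log units; beyond the scatter). Compound 3 carries a different core; how the core of compound 3 differs from the core of compound 1 is not broken down here. Compound 3 stands nearest to compound 2 and furthest from compound 1, both gaps within the usual scatter, so no order among the three is claimed.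

Compound 4, `CC1(C)[N+]([O-])=c2ccc(COc3ccccc3/C=N\NC(N)=S)cc2=[N+]1[O-]`, is not yet measured in this assay. It differs from compound 3 by a group of 3 heavy atoms (1 carbon, 1 nitrogen, 1 sulfur; no ring) in place of a group of 3 heavy atoms (1 carbon, 2 nitrogen; no ring), on an amine nitrogen, the same change as from compound 1 to compound 2, at the same place. Among the compounds with values here, because the only measured instance of this change is a 3.3-fold higher number from compound 1 to compound 2 (0.51 log units; beyond the scatter), the expected step is a 3.1-fold higher number from compound 3 to compound 4 (0.49 log units; beyond the scatter). Compound 4 is therefore estimated at 350 uM, with a likely range from 170 uM to 720 uM. The expectation rests on a single pair and is accordingly loose.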

Compound 4, concentration for 50% inhibition: > 200 uM
Compound 4 gave a limit, no number (the forecaster's own chance of this, stated with the estimate: 15%); the middle value lies beyond the limit too.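

In this assay compound 4 gives > 200 uM as a limit of the assay, not a number. On the core of compound 3 the change reads as an at least 1.7-fold higher number from compound 3 to compound 4 (0.24 log units; that floor lies within the scatter) and so points the same way as on the core of compound 1, but this floor alone does not establish a step beyond the scatter on this second core. The direction is therefore not contradicted, the size of the step is not shown to carry over, and the comparison between the two cores stays undecided: the same change on two cores in this assay, a 3.3-fold higher number (0.51 log units; beyond the scatter) from compound 1 to compound 2 and an at least 1.7-fold higher number (0.24 log units; that floor lies within the scatter) from compound 3 to compound 4; the limit leaves it open whether they differ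

With only two cores and one change shown, nothing here tells whether the change would read the same way on any further core, and a true number for compound 4 would be needed before the two steps could be set against each other. Also open, as far as these compounds go, is how a carbonyl oxygen in place of the sulfur, or a methyl group on the amine nitrogen of the group that changes, would read on either core.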